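Phenyl in Place of Pyridin-2-yl on a Shared Core

A few compounds are considered here, and "the series" means these few. Any claim that something is new, unique, unknown or untested is made for them only; others in the source may bear on it.

Compound 1 `C=C1C[C@]23C[C@@]1(O)CC[C@H]2c1ccc(O)c(C)c1[C@@H]3Cn1cc(-c2ccccn2)nn1` carries a pyridin-2-yl group on the five-membered aromatic ring with three nitrogens. In a functional assay on HL-60 cells (Homo sapiens) for cytotoxicity, read by MTT assay, with a stated time of 4 days (on this read-out lower numbers stand for stronger inhibition and higher numbers for weaker inhibition), compound 1 gives only a limit, > 20000 nM, and not a number. Two further compounds share this outcome. Compound 2 `C=C1C[C@]23C[C@@]1(O)CC[C@H]2c1ccc(OS(=O)(=O)c2ccc(C)cc2)c(C)c1[C@@H]3Cn1cc(-c2ccc(Br)cc2)nn1` returns a limit of > 20000 nM in this assay. Compound 3 `C=C1C[C@]23C[C@@]1(O)CC[C@@H]2c1cccc(C)c1[C@@H]3Cn1cc(-c2ccccn2)nn1` likewise gives a limit of > 20000 nM in this assay. Going by the values given here, all three values therefore sit at the limit of > 20000 nM in this assay, at which 3 of the 3 values shown sit, so no step between measured compounds can be sized, and compound 1 stands at that limit together with the other two.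

Compound 4 `C=C1C[C@]23C[C@@]1(O)CC[C@H]2c1ccc(O)c(C)c1[C@@H]3Cn1cc(-c2ccccc2)nn1` differs from compound 1 in one place: phenyl in place of pyridin-2-yl on an aromatic carbon. Among the compounds with values here, because every value shown sits at the limit of > 20000 nM in this assay, at which 3 of the 3 values shown sit, no measured step gives a direction for this change, and the expectation is that compound 4 remains at the limit, with no step beyond the scatter in this assay. Compound 4 is estimated at 25000 nM in this assay, within a range from 8000 nM to 80000 nM. The step expected from compound 1 to compound 4 is a step that the limit leaves unreadable from compound 1 to compound 4, that is, none that the assay would resolve, and most likely the read-out of compound 4 will again be reported only as a limit.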

Compound 4, half-maximal inhibitory concentration: > 20000 nM
Compound 4: a limit, no number (the forecaster's own chance of this, stated with the estimate: 80%); the middle value is on the limit's open side.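

Compound 4 gives > 20000 nM in this assay, which is a limit and not a number. No step from compound 1 to compound 4 can be read, because both results are limits: the limit of > 20000 nM in this assay, at which 4 of the 4 values shown sit.

The compounds shown leave open whether phenyl in place of pyridin-2-yl changes the read-out at all, as none of the four has a numerical value.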